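Methoxy in place of hydrogen on a flavone core

A few compounds are considered here, and "the series" means these few. Any claim that something is new, unique, unknown or untested is made for them only; others in the source may bear on it.

Compounds measured so far:
compound 1, `CS(=O)(=O)c1ccc(-c2oc3ccccc3c(=O)c2-c2cccc(Cl)c2)cc1` — < 5%
compound 2, `Cn1cc(-c2c(-c3ccc(S(C)(=O)=O)cc3)oc3ccccc3c2=O)cn1` — < 5%
compound 3, `CS(=O)(=O)c1ccc(-c2oc3ccccc3c(=O)c2-c2ccccc2)cc1` — < 5%

In an assay on isolated protein for inhibition of prostaglandin G/H synthase 1 (Mus musculus), tested at 10 ug/mL (on this read-out lower numbers stand for less inhibition and higher numbers for more inhibition at the one concentration tested (going by the name of the read-out)), compound 3 gives only a limit, < 5%, and not a number. Compound 1 likewise sits at a limit of this assay, < 5%. Compound 2 also reaches only a limit, < 5%. The three measured steps, a step that the two limits leave unreadable from compound 1 to compound 2, a step that the two limits leave unreadable from compound 1 to compound 3 and a step that the two limits leave unreadable from compound 2 to compound 3, are therefore all unreadable: each joins two limits, so their sizes cannot be told. The one thing the data show is the limit of < 5% in this assay, at which 3 of the 3 values shown sit.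

Compound 4, `COc1ccc(-c2c(-c3ccc(S(C)(=O)=O)cc3)oc3ccccc3c2=O)cc1`, differs from compound 3 by methoxy in place of hydrogen on an aromatic carbon. Within the data shown here, no measured step touches a methoxy group, so none bears directly on this change; the two steps that end at compound 3 are unreadable, and nothing in the set shows any compound of this core rising out of the limit.

On this basis compound 4 is expected to stay where compound 3 stands, with an estimated value of 3% (range 0% to 12%). The expected step is a step that the limit leaves unreadable from compound 3 to compound 4, within the usual scatter, with the result most likely reported again as a limit.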

Compound 4, a percentage reported as inhibition, at one concentration (the size of the read-out at that concentration, not a potency): < 5%
Compound 4: no number, only a limit; the forecaster's own chance of this, stated with the estimate: 80%; the middle value is on the limit's open side.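

Among these compounds, no step from compound 1, compound 2 or compound 3 to compound 4 can be read, since each joins two limits and not two numbers. The compounds shown leave open whether any change on the shared core brings inhibition out of that limit, and how large such a step would be, for all they show is this: the limit of < 5% in this assay, at which 4 of the 4 values shown sit.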